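The source may hold more compounds than are shown below. What is called first, only, known or untested is meant among the compounds shown, and "the series" means these compounds.

Of the compounds shown here, three built on one shared core have been tested in a functional assay on MDA-MB-231 cells (Homo sapiens) for cytotoxicity, read by MTT assay, with a stated time of 24 h; a higher number here means a weaker inhibitor, a lower number a stronger inhibitor. Compound 1 `FC(F)(F)Oc1cccc(-c2nc3cccnc3n2C2CCCC2)c1` gives 262 nM. Compound 2 `COC(=O)c1ccc(-c2nc3cccnc3n2C2CCCC2)cc1` gives 350 nM, and compound 3 `c1ccc(Cn2nccc2-c2nc3cccnc3n2C2CCCC2)cc1` gives 348 nM. Compound 2 carries the highest of the three numbers, yet compound 3 lies within the scatter of it and so does compound 1, so the three are not separated. For the measured compounds named here, compound 4 `c1cnc2c(c1)nc(-c1ccc(-c3nnco3)cc1)n2C1CCCC1` has not been measured; it differs from compound 2 in one place: 1,3,4-oxadiazol-2-yl in place of methoxycarbonyl on an aromatic carbon No measured pair shows a change of this kind, so the step in this assay is expected to stay within the scatter, in no firm direction. Compound 4 is therefore estimated at 330 nM, with a range from 150 nM to 750 nM. That estimate for compound 4 implies an expected step of a 1.1-fold lower number from compound 2 to compound 4 (0.03 log units; within the scatter).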

Compound 4, half-maximal inhibitory concentration: 87 nM
Compound 4: the middle estimate sits 3.8-fold (0.58 log units) above what was measured, and the stated range ends above it.
By their numbers in this assay, from the lowest: compound 4; then compounds 1, 3 and 2 (each within the scatter of the next).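

In this assay, for the compounds shown here, the place on the six-membered aromatic ring of carbon only, para to a large group, responds to what it carries: 1,3,4-oxadiazol-2-yl in place of methoxycarbonyl gives a 4.0-fold lower number from compound 2 to compound 4 (0.60 log units; beyond the scatter) and is the only step here beyond the scatter. The earlier compounds shown here, all within the scatter of one another, showed no such separation. Nothing measured here bears on the reason for this step. Still open, going by these compounds, is how a carboxylic acid, a primary amide or a nitrile would fare at this place, and whether a five-membered aromatic ring with other hetero atoms would match compound 4.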